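A Phenyl Swap in a Lipase Inhibitor Pair

The source may hold more compounds than are shown below. What is called first, only, known or untested is meant among the compounds shown, and "the series" means these compounds.

Measured compounds:
compound 1, `O=C(N1CCCC[C@@H]1Cc1ccccc1)n1ncc(C(O)(c2ccc(F)cc2)c2ccc(F)cc2)n1`, 0.794 nM
compound 2, `O=C(N1CCCCC1COc1ccc(F)cc1)n1ncc(C(O)(c2ccc(F)cc2)c2ccc(F)cc2)n1`, 5.01 nM

In an assay on HEK-293T cells for inhibition of diacylglycerol lipase-alpha (Homo sapiens), read by colorimetric assay (a lower number here means a stronger inhibitor, a higher number a weaker inhibitor), compound 1 gives 0.794 nM, while compound 2 gives 5.01 nM. Compound 2 therefore stands highest of the two numbers shown; its only neighbour is compound 1, whose value lies lower by a margin beyond the usual scatter, so compound 2 is the weaker inhibitor of the pair.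

Compound 3, `O=C(N1CCCCC1Cc1ccccc1)n1ncc(C(O)(c2ccc(F)cc2)c2ccc(F)cc2)n1`, arises from compound 2 by phenyl in place of 4-fluorophenoxy on a saturated chain carbon bound to a saturated ring carbon. For the measured compounds named here, no pair of measured compounds shows exactly this change, so the expectation can rest only on the two values in hand. Compound 1 already carries the benzyl group that enters here and gives 0.794 nM in this assay, which points to a drop for compound 3 that goes beyond the scatter rather than a shift within it. The step that this estimate means is a 3.3-fold lower number from compound 2 to compound 3 (0.52 log units; beyond the scatter), expected to land the new compound close to the lower of the two measured numbers. Compound 3 is accordingly estimated at 1.5 nM, with a range from 0.5 nM to 5 nM.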

Compound 3, half-maximal inhibitory concentration: 1 nM
For compound 3 the middle estimate is 1.5-fold (0.18 log units) above the measured one; measured number inside the range.
By their numbers in this assay, from the lowest: compounds 1 and 3 (each within the scatter of the next); then compound 2.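

In this assay, for the compounds shown here, replacing 4-fluorophenoxy with phenyl on a saturated chain carbon bound to a saturated ring carbon gives a 5.0-fold lower number from compound 2 to compound 3 (0.70 log units; beyond the scatter), the first step at this position that can be read directly between two compounds differing in one place. Read one bond further out, it is a change from (4-fluorophenoxy)methyl to benzyl, and it shows that this position responds to the group it carries by more than the usual scatter. Going by these compounds alone, the other step, a 1.3-fold higher number from compound 1 to compound 3 (0.10 log units; within the scatter), stays within the scatter, and only one feature separates that pair: the fact that one of compounds 1 and 3 is drawn with a defined configuration and the other without, at the place where they differ.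

The step from compound 2 to compound 3 removes the oxygen and the fluorine together, so it leaves open which of the two accounts for the difference, a question that a 4-fluorobenzyl or an unsubstituted phenoxymethyl group at the same place could settle. The compounds shown also leave open how a form drawn with the S configuration at this stereocentre would compare, and whether compound 3 represents a single form or a mixture.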